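A few compounds are considered here, and "the series" means these few. Any claim that something is new, unique, unknown or untested is made for them only; others in the source may bear on it.

In a functional assay on MCF7 cells (Homo sapiens) for antiproliferative activity, read by CellTiter-Glo, with a stated time of 5 days (on this read-out lower numbers stand for stronger inhibition and higher numbers for weaker inhibition), compound 1 (`CC1=C(c2cccc(O)c2)C(c2ccc(OC[C@H](C)N3CCCC3)cc2)Oc2ccc(O)cc21`) gives 0.2 nM, while compound 2 (`CC1=C(c2ccccc2)C(c2ccc(OC[C@H](C)N3CC[C@@H](C)C3)cc2)Oc2ccc(O)cc21`) gives 0.4 nM. For the measured compounds named here, these two values lie within the usual scatter of each other, so they do not separate the two compounds, and compound 1 sits in the same sub-nanomolar range as the only other measured member of the series.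

Compound 3 (`CC1=C(c2cccc(O)c2)C(c2ccc(OC[C@H](C)N3CC[C@H](C)C3)cc2)Oc2ccc(O)cc21`) keeps the core of compound 1 and changes the amine ring, from pyrrolidin-1-yl to 3-methylpyrrolidin-1-yl (methyl in place of hydrogen on a saturated ring carbon). This places methyl in place of hydrogen on a saturated ring carbon, two ring bonds from the ring nitrogen.

Going by the values given here, no measured pair isolates this change. The nearest guide is compound 2, which also bears a 3-methylpyrrolidin-1-yl group and still gives 0.4 nM, but it differs from compound 3 elsewhere too, so it is only a loose reference. In this assay, the expected 2.0-fold higher number from compound 1 to compound 3 (0.30 log units; within the scatter) is therefore small, at most slightly toward a higher number and probably not beyond the scatter. The estimated value for compound 3 is 0.4 nM, with an expected range of 0.12 nM to 1.5 nM.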

Compound 3, half-maximal inhibitory concentration: 0.2 nM
Estimate against measurement, compound 3: 2.0-fold (0.30 log units) above; low and high end bracket the measured number.
By their numbers in this assay, from the lowest: compounds 1, 3 and 2 (each within the scatter of the next).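

In this assay the step reads no change at the digits printed from compound 1 to compound 3 (within the scatter) for methyl in place of hydrogen on a saturated ring carbon, two ring bonds from the ring nitrogen. For the compounds shown here, this is the first reading of the change on its own: compound 2 also carries 3-methylpyrrolidin-1-yl but differs from compound 3 elsewhere too, whereas the pair of compound 1 and compound 3 holds the rest of the structure fixed and shows that this ring carbon takes the added methyl with no separable shift in this read-out. No measurement at hand explains why the reading holds.

Going by these compounds, the result covers one small group at one ring carbon, so what an ethyl group, a hydroxyl group, an amine or a carboxylic acid would give at the same place remains open. It is also a single pair on the core of compound 1, and whether pyrrolidin-1-yl to 3-methylpyrrolidin-1-yl reads the same on another core cannot be told from these compounds.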